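A Ring Swap Where Little Change Is Expected

This account rests on a few compounds, and the source may have more. Where it says the series, first, only, none or still open, it means among the compounds named here.

Compound 1 `O=C1N/C(=N/c2ccc(Cl)cc2)S/C1=C\c1ccccn1` and compound 2 `COc1ccc(/N=C2\NC(=O)/C(=C/c3ccccn3)S2)cc1` share one core and differ only in the ring attached to a double-bonded nitrogen. In a functional assay on the whole organism (strain Wistar) for inhibition, with Rattus norvegicus as the target, read by paw edema, with stated times of 30 min and 120 min, at a dose of 10 mg/kg by the oral route (a higher number here means more inhibition at the dose given (going by the name of the read-out), a lower number less inhibition), compound 1 gives 34.8%; compound 2 gives 39.1%, a gap within the usual scatter, so neither stands apart from the other. Compound 3 `Cc1ccccc1/N=C1/NC(=O)/C(=C/c2ccccn2)S1` has not been measured; it differs from compound 1 by 2-methylphenyl in place of 4-chlorophenyl on a double-bonded nitrogen. Among the compounds with values here, no measured pair shows how such a change moves the read-out, so nothing beyond the scatter, in either direction, is expected. Compound 3 is therefore estimated at 35%, with a range from 20% to 50%. The expected step is a number 0.2 percentage points higher from compound 1 to compound 3 (within the scatter).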

Compound 3, a percentage reported as inhibition, in the whole organism at one dose (the size of the read-out at that dose, not a potency): 30.4%
Beside the measured number, compound 3's estimate is 4.6 percentage points above it, within the range that was stated.
By their numbers in this assay, from the lowest: compounds 3, 1 and 2 (each within the scatter of the next).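

In this assay, within the data shown here, 2-methylphenyl in place of 4-chlorophenyl on a double-bonded nitrogen gives a number 4.4 percentage points lower from compound 1 to compound 3 (within the scatter) and so provides the first direct reading of a single change at this place. Between these two groups, the step cannot be told apart from the usual scatter at this dose. No available evidence bears on this result.

The compounds shown leave open whether a larger step could come from a different group here. An amine or a carboxylic acid on the ring, or a longer chain in place of the ring, remains to be compared.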